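Methyl removal in the acylguanidine series: outlook for compound 4

The source may hold more compounds than are shown below. What is called first, only, known or untested is meant among the compounds shown, and "the series" means these compounds.

Compound 1 `CCCc1cc(C)c(C(=O)N=C(N)N)cc1S(C)(=O)=O` in a functional assay for inhibition of sodium/hydrogen exchanger (Oryctolagus cuniculus) (a lower number here means a stronger inhibitor, a higher number a weaker inhibitor), gives 5.7 nM. Compound 2 `CCOc1cc(C)c(C(=O)N=C(N)N)cc1S(C)(=O)=O` gives 19 nM, and compound 3 `Cc1cc(N2CCC(N)CC2)c(S(C)(=O)=O)cc1C(=O)N=C(N)N` gives 9.8 nM; compound 3 thus holds the second highest of the three numbers, within the scatter of both compound 1 and compound 2, so no order among them can be read. Compound 4 `CS(=O)(=O)c1cc(C(=O)N=C(N)N)ccc1N1CCC(N)CC1` differs from compound 3 by hydrogen in place of methyl on an aromatic carbon. Among the compounds with values here, no measured step touches this methyl: the steps of a 1.7-fold higher number from compound 1 to compound 3 (0.24 log units; within the scatter) and a 1.9-fold lower number from compound 2 to compound 3 (0.29 log units; within the scatter) exchange the other substituent and stayed within the scatter, while a 3.3-fold higher number from compound 1 to compound 2 (0.52 log units; beyond the scatter) was modest. Removing the methyl is therefore expected to give a 1.5-fold higher number from compound 3 to compound 4 (0.18 log units; within the scatter), nothing beyond the scatter. Compound 4 is estimated at 15 nM, between 5 nM and 45 nM.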

Compound 4, half-maximal inhibitory concentration: 160 nM
The estimate for compound 4 lay 11-fold (1.03 log units) below the measured number; the measured number lies above the stated range.
By their numbers in this assay, from the lowest: compounds 1, 3 and 2 (each within the scatter of the next, the first and the last beyond it); then compound 4.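

Hydrogen in place of methyl on this aromatic carbon, para to the methylsulfonyl group and meta to the 4-aminopiperidin-1-yl group, gives in this assay a 16-fold higher number from compound 3 to compound 4 (1.21 log units; beyond the scatter), a large step. This one carbon therefore counts for more than any exchange of the other substituent shown, the largest of which is a 3.3-fold higher number from compound 1 to compound 2 (0.52 log units; beyond the scatter). Nothing measured here accounts for the size of this step.

From the compounds shown here alone, whether an ethyl, a methoxy or a chlorine at this carbon would hold the number of compound 3 remains open. Also open, going by these compounds, is whether hydrogen costs as much with propyl or ethoxy in place of the 4-aminopiperidin-1-yl group.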